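The compounds below may be only part of what the source reports. "The series", "measured", "known", "first", "only" and "open" are said of these compounds alone.

Series notes. Compound 1 `COc1ccccc1/C=c1\c(=O)[nH]/c(=C/c2cccc(Cl)c2Cl)c(=O)n1C` carries a 2-methoxyphenyl and a 2,3-dichlorophenyl on the shared core; in a functional assay on MOLT-4 cells (Homo sapiens) for cytotoxicity, read by CCK-8 assay, with a stated time of 72 h (on this read-out lower numbers stand for stronger inhibition and higher numbers for weaker inhibition), compound 1 is reported as "not determined" (no result reported), with no result given. Compound 2 `C=CCn1c(=O)/c(=C\c2ccc(Cl)c(Cl)c2)[nH]c(=O)/c1=C\c1ccccc1` is reported in this assay as "not active" (no number reported), without a number. Among the compounds with values here, compound 3 `C=CCn1c(=O)/c(=C\c2cccc(F)c2)[nH]c(=O)/c1=C\c1ccccc1OC` gives 6500 nM in this assay, the only number in the set so far, so it stands as the single reference point. Within the data shown here, nothing else is measured, and no step between measured compounds can be compared.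

Compound 4 `C=CCn1c(=O)/c(=C\c2ccccc2OC)[nH]c(=O)/c1=C\c1ccccc1OC` differs from compound 3 in one place: 2-methoxyphenyl in place of 3-fluorophenyl on a double-bonded chain carbon bound to an aromatic carbon. Both halves of compound 4 now carry the 2-methoxyphenyl already present in compound 3. With a single number to lean on, no direction is supported by the data; the expected step from compound 3 to compound 4 is a 1.2-fold higher number from compound 3 to compound 4 (0.09 log units; within the scatter), which is treated as no change beyond the scatter. Compound 4 is accordingly estimated at 8000 nM, with a range from 2500 nM to 25000 nM in this assay.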

Compound 4, half-maximal inhibitory concentration: 13100 nM
Beside the measured number, compound 4's estimate is 1.6-fold (0.21 log units) below it, within the range that was stated.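

In this assay, within the data shown here, the exchange of 3-fluorophenyl for 2-methoxyphenyl on a double-bonded chain carbon bound to an aromatic carbon gives a 2.0-fold higher number from compound 3 to compound 4 (0.30 log units; within the scatter), the first step that can be read at all. At this position, then, a group with one hydrogen-bond acceptor in place of a fluorinated ring with none leaves the number inside the usual scatter of the read-out, so the two compounds cannot be told apart here. No measured data bear on what lies behind this result.

Steps to compound 1 and compound 2 cannot be read, since neither has a number. On these data alone, whether an amine, a carboxylic acid or a longer chain at this position would move the number beyond the scatter remains open.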